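Swapping the aryl on the triazole nitrogen of compound 3

A few compounds are considered here, and "the series" means these few. Any claim that something is new, unique, unknown or untested is made for them only; others in the source may bear on it.

Measured compounds:
- compound 1 `O[C@H](COCCOC[C@@H](O)Cc1cn(Cc2ccc3ccccc3c2)nn1)Cc1ccc(-c2ccccc2)cc1`: 8600 nM
- compound 2 `O[C@H](COCCOC[C@@H](O)Cc1cn(-c2cccs2)nn1)Cc1ccc(-c2ccccc2)cc1`: 33400 nM
- compound 3 `O[C@H](COCCOC[C@@H](O)Cc1cn(-c2cccnc2)nn1)Cc1ccc(-c2ccccc2)cc1`: 46800 nM

These three compounds share one core and differ only in the group on the aromatic nitrogen of the triazole. In a functional assay on HCT-116 cells (Homo sapiens) for inhibition, read by MTT assay, with a stated time of 72 h (on this read-out higher numbers stand for weaker inhibition of growth and lower numbers for stronger inhibition of growth), compound 3 gives the highest number of the three. The smaller of its two gaps is within the scatter (a 1.4-fold higher number from compound 2 to compound 3 (0.15 log units; within the scatter)), whereas the larger one is clear (a 5.4-fold higher number from compound 1 to compound 3 (0.74 log units; beyond the scatter)), and the remaining step between the other two measured compounds is clear in the same way (a 3.9-fold higher number from compound 1 to compound 2 (0.59 log units; beyond the scatter)).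

Compound 4 `O[C@H](COCCOC[C@@H](O)Cc1cn(-c2ccc3c(c2)OCCO3)nn1)Cc1ccc(-c2ccccc2)cc1` carries the change (2,3-dihydro-1,4-benzodioxin-6-yl in place of pyridin-3-yl on an aromatic nitrogen). Like compounds 2 and 3 it bears an aryl group directly on that nitrogen, and the two measured steps that bear on the question, from compound 1 to compound 2 and from compound 1 to compound 3, both show that such direct aryl groups gave weaker inhibition than the naphthalenylmethyl group of compound 1. Nothing measured separates one direct aryl group from another beyond the scatter. Compound 4 is therefore expected to land near compounds 2 and 3, with an estimated step of a 1.5-fold lower number from compound 3 to compound 4 (0.17 log units; within the scatter) that stays within the scatter. The estimate for compound 4 is 32000 nM, with a range from 10000 nM to 90000 nM.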

Compound 4, concentration for 50% growth inhibition: 16500 nM
Compound 4: the middle estimate sits 1.9-fold (0.29 log units) above what was measured; the measured number falls inside the stated range.
By their numbers in this assay, from the lowest: compounds 1 and 4 (each within the scatter of the next); then compounds 2 and 3 (each within the scatter of the next).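

The result shows that groups attached directly to the aromatic nitrogen of the triazole do not all behave alike. In this assay, 2,3-dihydro-1,4-benzodioxin-6-yl separates beyond the scatter from both earlier direct ring groups, with a 2.8-fold lower number from compound 3 to compound 4 (0.45 log units; beyond the scatter) and a 2.0-fold lower number from compound 2 to compound 4 (0.31 log units; beyond the scatter). At the same time, a 1.9-fold higher number from compound 1 to compound 4 (0.28 log units; within the scatter) places a directly attached ring level with the (naphthalen-2-yl)methyl group, so the gap seen earlier does not hold for every direct ring, and nothing available here explains these differences.

As far as these compounds go, it remains open whether the non-aromatic ring with its two oxygens matters, which a plain phenyl or a phenyl carrying two separate methoxy groups on this nitrogen could help to settle. From the compounds shown here alone, the effect of an amine or a carboxylic acid on the ring at this position also remains unknown.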